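A Ring Swap at the Limit of the Assay

This account rests on a few compounds, and the source may have more. Where it says the series, first, only, none or still open, it means among the compounds named here.

Measured in a functional assay on BXPC-3 cells (Homo sapiens) for inhibition, read by MTT assay, with a stated time of 72 h; a lower number here means a stronger inhibitor, a higher number a weaker inhibitor:
Compound 1 `O=C(Nc1cccc2cccnc12)c1cccc(Br)n1`: > 10000 nM (a limit)
Compound 2 `Cc1cnc(C(=O)Nc2cccc3ccc(C)nc23)cn1`: > 10000 nM (a limit)

Neither measured compound has an actual number. Compound 1 reads > 10000 nM, which is a limit of this assay and not a number. Compound 2 stands at the limit of > 10000 nM in this assay, at which 2 of the 2 values shown sit, so it too has only a limit to show.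

The next compound, compound 3 `Cc1ccc2cccc(NC(=O)c3ncccn3)c2n1`, keeps the core of compound 2 and changes one group: pyrimidin-2-yl in place of 5-methylpyrazin-2-yl on a carbonyl carbon.

Going by the values given here, no measured pair here differs in a single place, so the data do not show how large such a swap can be. No step beyond the usual scatter is expected in this assay. That expectation rests on compound 2 at > 10000 nM, a limit and not a number. Compound 3 may well be reported only as a limit too. The estimated step runs a step that the limit leaves unreadable from compound 2 to compound 3. For compound 3 the estimate is 12000 nM, with an expected range from 4000 nM to 40000 nM.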

Compound 3, half-maximal inhibitory concentration: > 10000 nM
Compound 3 was reported as a limit; the forecaster's own chance of this, stated with the estimate: 80%; the middle value lies beyond the limit too.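

No step can be read from compound 2 to compound 3, because each is reported only as a limit and not as a number: the limit of > 10000 nM in this assay, at which 3 of the 3 values shown sit.

The compounds shown leave open how strongly any of them inhibits these cells, and whether any group on the carbonyl carbon would give a value that can be read as a number.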